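The source may hold more compounds than are shown below. What is called first, only, known or untested is meant among the compounds shown, and "the series" means these compounds.

Measured so far:
- compound 1, `COc1cccc(F)c1-c1cc(C(=O)N[C@@H](CCN2CCCCC2)CC(=O)NC2CCC2)nn1C1CCCC1`: 74.3%
- compound 2, `O=C(C[C@H](CCc1ccc(F)cc1)NC(=O)c1cc(-c2ccccc2C(F)(F)F)n(C2CCCC2)n1)NC1CCC1`: "nd" (no result reported)
- compound 3, `CCc1cc(F)ccc1-c1cc(C(=O)N[C@@H](CCN2CCCCC2)CC(=O)NC2CCC2)nn1C1CCCC1`: "nd" (no result reported)

Three compounds were tested in an ADME assay on microsomes from liver (Rattus norvegicus, strain Sprague-Dawley) for metabolic stability, read by LC-MS, using NADPH, with a stated time of 30 min, tested at 1 uM (on this read-out lower numbers stand for a less stable compound and higher numbers for a more stable compound), and only one of them returned a number. Compound 1 gives 74.3% in this assay; compound 2 gives "nd" (no result reported) and compound 3 gives "nd" (no result reported), so compound 1 stands alone among the measured entries, with nothing to rank it against. For the measured compounds named here, no step between two measured compounds can be drawn from these data.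

The compound that remains to be measured is compound 4, `O=C(C[C@H](CCN1CCCCC1)NC(=O)c1cc(-c2ccccc2C(F)(F)F)n(C2CCCC2)n1)NC1CCC1`. Relative to compound 1 it carries a single change: 2-(trifluoromethyl)phenyl in place of 2-fluoro-6-methoxyphenyl on an aromatic carbon. The shared core, the cyclopentyl group and the whole amide-bearing side chain are unchanged.

Going by the values given here, with no measured step to rest on, the expectation for compound 4 in this assay rests on compound 1 alone, whose 74.3% is the only anchor available. Compound 4 is estimated at 76%, with a range from 60% to 92%. The step this estimate means, a number 1.7 percentage points higher from compound 1 to compound 4 (within the scatter), is expected to be small and to lie within the usual scatter of this kind of measurement, in no clear direction.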

Compound 4, percent of the compound remaining: 74.6%
Beside the measured number, compound 4's estimate is 1.4 percentage points above it, and the stated range covers the measured number.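

In this assay, for the compounds shown here, 2-(trifluoromethyl)phenyl in place of 2-fluoro-6-methoxyphenyl gives a number 0.3 percentage points higher from compound 1 to compound 4 (within the scatter), which is the first step that can be read. On this aromatic carbon, next to the ring atom that bears a cyclopentyl group, the read-out therefore does not tell these two aryl groups apart, even though they share only the six-membered aromatic ring of carbon and differ in their substituents. No measurement shown offers a reason for this result.

The steps to compound 2 and compound 3 cannot be read, so the data give no second aryl comparison on this core and do not show whether the 2-(trifluoromethyl)phenyl group behaves the same way beside a different side chain. Also open, on these data alone, is whether the same holds for quite different groups at this place, such as an unsubstituted phenyl, a pyridine ring or a phenyl bearing a nitrile, or for a carboxylic acid in place of the piperidine at the end of the side chain.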